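The source may hold more compounds than are shown below. What is called first, only, known or untested is meant among the compounds shown, and "the series" means these compounds.

Measured so far:
Compound 1, `O=C(O)c1cnc2cc(S(=O)(=O)O)ccc2c1O`: 3090000 nM
Compound 2, `O=C(O)c1cnc2cc(OCCc3ccc(Br)cc3)ccc2c1O`: 91200 nM

Both numbers come from an assay on isolated protein with malate dehydrogenase, cytoplasmic (Sus scrofa) as the target; a higher number here means a weaker inhibitor, a lower number a stronger inhibitor. Of the two, compound 1 stands highest: the gap to compound 2 lies well beyond the usual scatter of this assay, so compound 1 is clearly the weaker inhibitor of the pair. Compound 3, `O=C(O)c1cnc2cc(O)ccc2c1O`, has not yet been measured in this assay. It differs from compound 1 in one place: hydroxy in place of sulfo on an aromatic carbon. Among the measured compounds shown here, no measured pair that differs in just one place is available, so the size of this step can only be expected, not read off. Compound 2 shows that the shared core can reach a far lower number than compound 1 when the group at this position is changed, and on that basis a lower number is expected for compound 3, smaller in size than the difference compound 2 shows. For compound 3 the expected step is a 3.1-fold lower number from compound 1 to compound 3 (0.49 log units; beyond the scatter). The estimate for compound 3 is 1000000 nM, in the range 200000 nM to 5000000 nM.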

Compound 3, half-maximal inhibitory concentration: 955000 nM
For compound 3 the middle estimate is 1.0-fold (0.02 log units) above the measured one; low and high end bracket the measured number.
By their numbers in this assay, from the lowest: compound 2; then compound 3; then compound 1.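

In this assay, among the compounds shown here, this is the first direct reading at this position: hydroxy in place of sulfo on the aromatic carbon gives a 3.2-fold lower number from compound 1 to compound 3 (0.51 log units; beyond the scatter) and this modest step lies beyond the scatter. So the sulfo group is not required for the weak inhibition seen with compound 1, and a much smaller group gives a somewhat lower number. No measurement at hand explains why the number falls with this swap.

An amine or a methoxy group at this position would show how other small groups compare with hydroxy. On these data alone, compound 2 gives 91200 nM with its 4-bromophenyl-bearing chain, and it remains open whether the chain length, the ring or the bromine matters most for that number.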